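The compounds below may be only part of what the source reports. "The series", "measured", "known", "first", "only" and "open" are said of these compounds alone.

Among the compounds with values here, in a functional assay on A-431 cells (Homo sapiens) for inhibition, read by sulforhodamine B assay, with a stated time of 2 days (on this read-out lower numbers stand for stronger inhibition of growth and higher numbers for weaker inhibition of growth), three compounds have numbers so far. Compound 1 `CC1=C(C(=O)Nc2ccc(C)cc2)C(c2ccc(O)cc2O)NC(SCc2ccccc2)=N1` gives 20800 nM, compound 2 `CC1=C(C(=O)Nc2ccc(C)cc2)C(c2ccc(O)cc2O)NC(Nc2ccc([N+](=O)[O-])cc2Cl)=N1` gives 31900 nM and compound 3 `Cc1ccc(NC(=O)c2c(C)nc(S(=O)(=O)Cc3ccccc3)nc2-c2ccc(O)cc2O)cc1` gives 32000 nM, which places compound 3 within the usual scatter of the other two. Compound 4 `Cc1nc(S(=O)(=O)Cc2ccccc2)nc(-c2ccc(O)cc2O)c1C(=O)Nc1cccc([N+](=O)[O-])c1` differs from compound 3 in one place: 3-nitrophenyl in place of 4-methylphenyl on an amide-type nitrogen. In short, 3-nitrophenyl stands in place of 4-methylphenyl on an amide-type nitrogen. Within the data shown here, no measured step touches this group. Among the measured compounds shown here, the only step available, a 1.5-fold higher number from compound 1 to compound 2 (0.19 log units; within the scatter), lies elsewhere in the molecule and offers weak guidance. On these data alone, no step beyond the scatter is therefore expected in this assay, and the direction remains open. The estimated step is a 1.3-fold lower number from compound 3 to compound 4 (0.11 log units; within the scatter). Compound 4 is expected at 25000 nM, with an estimated range from 10000 nM to 60000 nM.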

Compound 4, concentration for 50% growth inhibition: 28900 nM
The estimate for compound 4 lay 1.2-fold (0.06 log units) below the measured number; the range from low to high includes it.
By their numbers in this assay, from the lowest: compounds 1, 4, 2 and 3 (each within the scatter of the next).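

In this assay, within the data shown here, 3-nitrophenyl in place of 4-methylphenyl on the amide-type nitrogen gives the first measured step at this position (a 1.1-fold lower number from compound 3 to compound 4 (0.04 log units; within the scatter)), and that step lies within the scatter. The two groups differ in their atoms, and only 3-nitrophenyl carries hydrogen-bond acceptors, yet this exchange does not separate compound 3 from compound 4. Nothing measured here accounts for this result.

On these data alone, whether an amine or a carboxylic acid on this aromatic ring would give a step beyond the scatter remains open. The same holds for a longer chain in place of the ring.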